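The source may report more compounds than this note shows. Statements on the series, on what has been measured and on what is new or still open speak of the compounds shown alone.

Measured in a functional assay on MDA-MB-231 cells (Homo sapiens), read by microscopy and transwell migration, with a stated time of 24 h; a lower number here means a stronger inhibitor, a higher number a weaker inhibitor:
- compound 1 `O=C(Nc1nc(-c2ccccc2Cl)cs1)c1ccccc1`: 15000 nM
- compound 2 `O=C(Nc1nc(-c2ccc(Br)cc2)cs1)c1ccccc1`: 9500 nM
- compound 3 `O=C(Nc1nc(-c2cccc(Cl)c2)cs1)c1ccccc1`: 123 nM

Compound 1 carries the highest of these three numbers. The nearest step, a 1.6-fold lower number from compound 1 to compound 2 (0.20 log units; within the scatter), lies within the scatter, while the furthest, a 120-fold lower number from compound 1 to compound 3 (2.09 log units; beyond the scatter), lies well beyond it.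

Compound 4 `CN(C(=O)c1ccccc1)c1nc(-c2ccccc2Cl)cs1` differs from compound 1 in one place, with methyl in place of hydrogen on an amide-type nitrogen. Within the data shown here, none of the measured steps touches that nitrogen. All of them exchange the chlorophenyl or bromophenyl group, so they give no direction for this change. Among the measured compounds shown here, they show only that a single exchange on this core can stay within the scatter or be large, as a 77-fold lower number from compound 2 to compound 3 (1.89 log units; beyond the scatter) also is. No step beyond the scatter can therefore be expected in a particular direction, though a wide range is needed. The estimated step is a 1.5-fold lower number from compound 1 to compound 4 (0.18 log units; within the scatter), which would stay within the scatter. For compound 4 the expected value is 10000 nM, with an estimated range of 1000 nM to 40000 nM.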

Compound 4, half-maximal inhibitory concentration: 41.6 nM
Compound 4: middle estimate off by 240-fold (2.38 log units), on the high side; measured number below the stated range.
By their numbers in this assay, from the lowest: compound 4; then compound 3; then compounds 2 and 1 (each within the scatter of the next).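

Among these compounds, on the amide-type nitrogen, which none of the earlier steps touched, methyl in place of hydrogen gives a 360-fold lower number from compound 1 to compound 4 (2.56 log units; beyond the scatter) in this assay, so the amide hydrogen is not required for a low number here. The earlier steps shown here had left the 2-chlorophenyl group with a high number, yet compound 4 keeps that group and still reaches a low one, so the high number of compound 1 does not follow from the 2-chlorophenyl group alone. The information available offers no explanation for the size of this step.

Whether the step belongs to methyl in particular stays open, since ethyl or a longer chain on this nitrogen is not among the compounds shown. They also leave open whether methyl here would change the number in the same direction alongside the 3-chlorophenyl group of compound 3.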